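The source may report more compounds than this note shows. Statements on the series, on what has been measured and on what is new or still open speak of the compounds shown alone.

Compound 1 `Nc1ccccc1-c1ncc(C(=O)O)c(=O)[nH]1` carries an amino group and gives 50 mg/kg in a functional assay on the whole organism (strain Sprague-Dawley) for inhibition, with Rattus norvegicus as the target, with a stated time of 10 min; a higher number here means that more compound is needed for the effect, a lower number that less compound is needed. Compound 2 `C=CCOc1ccccc1-c1ncc(C(=O)O)c(=O)[nH]1` carries allyloxy instead, and in this assay compound 2 gives 0.5 mg/kg; the shift is a 100-fold lower number from compound 1 to compound 2 (2.00 log units; beyond the scatter). Compound 3 `CCOC(=O)c1cnc(-c2ccccc2N)[nH]c1=O` is the ethyl ester of compound 1, and in this assay compound 3 gives "not determined" (no result reported); it therefore stands on no number at all. Compound 4 `CCOC(=O)c1cnc(-c2ccccc2OCc2ccccc2)[nH]c1=O` differs from compound 3 by benzyloxy in place of amino on an aromatic carbon. Among the compounds with values here, the only step that bears on this change is the one from compound 1 to compound 2, which was large and ran toward a lower dose. A step of comparable direction is expected here, though the ester pair has no measured anchor. Compound 4 is estimated to give about 1 mg/kg in this assay, likely between 0.15 mg/kg and 8 mg/kg.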

Compound 4, dose for 50% inhibition: > 5 mg/kg
Compound 4: only a limit was reported; the forecaster's own chance of this, stated with the estimate: 10%; middle value at least 5.0-fold (0.69 log units) away from the limit.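

Within the data shown here, compound 3 carries no number and compound 4 only a limit, so no step between compound 3 and compound 4 can be read in this assay. The compounds shown leave open how benzyloxy in place of amino changes the dose for the ethyl esters.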